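Chloro for Fluoro in a Series Sitting at the Assay Limit

A few compounds are considered here, and "the series" means these few. Any claim that something is new, unique, unknown or untested is made for them only; others in the source may bear on it.

Compound 3 `Fc1ccc(Nc2nc(-c3cccc(F)c3)nc3ccc(F)cc23)cc1` was tested in a functional assay on MCF7 cells (Homo sapiens) for cytotoxicity, read by MTT assay, with a stated time of 48 h (a higher number here means a weaker inhibitor, a lower number a stronger inhibitor), where compound 3 gives > 50000 nM, a limit of the assay rather than a number. Its relatives show the same picture. In this assay compound 1 `Fc1cccc(-c2nc(Nc3ccccc3)c3ccccc3n2)c1` gives > 50000 nM, again a limit. In this assay compound 2 `COc1ccccc1Nc1nc(-c2cccc(F)c2)nc2ccc(F)cc12` gives > 50000 nM, likewise a limit. Among the measured compounds shown here, the one measured step between these compounds, a step that the two limits leave unreadable from compound 2 to compound 3, cannot be read because both ends are limits. For the measured compounds named here, the only evidence bearing on such steps is the limit of > 50000 nM in this assay, at which 3 of the 3 values shown sit.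

Compound 4 `Fc1cccc(-c2nc(Nc3ccc(Cl)cc3)c3cc(F)ccc3n2)c1` differs from compound 3 by chloro in place of fluoro on an aromatic carbon. No readable step in this assay tells the size or direction of such an exchange, so no change beyond the scatter can be expected from it. The expected step is a step that the limit leaves unreadable from compound 3 to compound 4. Compound 4 is therefore estimated to give 60000 nM in this assay, within a range from 20000 nM to 200000 nM, most likely reported again only as a limit.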

Compound 4, half-maximal inhibitory concentration: > 50000 nM
Compound 4 ended at the assay's limit (the forecaster's own chance of this, stated with the estimate: 80%); the middle value lies beyond the limit too.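

Neither new step, from compound 3 or compound 2 to compound 4, can be read in this assay because both ends of each are only limits of the assay: the limit of > 50000 nM in this assay, at which 4 of the 4 values shown sit. The compounds shown leave open what size or direction these exchanges have, and whether any relative of the shared core gives a readable value in this assay.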